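The source may hold more compounds than are shown below. What is called first, only, known or untested is meant among the compounds shown, and "the series" means these compounds.

Working notes on the series. Compound 2 `Nc1ccc(-n2c(-c3cccnc3N)nc3cccnc32)cc1` gives 740 nM in an in vitro assay on Sf9 cells for inhibition of RAC-alpha serine/threonine-protein kinase (Homo sapiens), read by AlphaScreen, with a stated time of 20 min (on this read-out higher numbers stand for weaker inhibition and lower numbers for stronger inhibition), the highest of the three numbers in hand. Among the compounds with values here, compound 1 `Nc1ncccc1-c1nc2cc(C3CCCC3)cnc2n1-c1ccc(CNC(=O)c2ccccc2)cc1` gives 110 nM and compound 3 `Nc1ncccc1-c1nc2cc(-c3cccnc3)cnc2n1-c1ccc(CNC(=O)c2ccccc2)cc1` gives 8 nM; both carry a substituent on the core and a benzamide on the pendant phenyl ring, so each differs from compound 2 in more than one place and no single step to compound 2 can be read from them.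

Compound 4 `CC(=O)Nc1ccc(-n2c(-c3cccnc3N)nc3cccnc32)cc1` is compound 2 with acetyl in place of hydrogen on a nitrogen on an aromatic ring. Within the data shown here, the only measured step, a 14-fold lower number from compound 1 to compound 3 (1.14 log units; beyond the scatter), concerns the substituent on the core, not the nitrogen on the aromatic ring, so it does not bear on this change. Among the measured compounds shown here, no measured pair speaks to acylation of that nitrogen. The expectation therefore rests on the fact that compounds 1 and 3 tolerate an amide on the pendant phenyl ring while still giving lower numbers than compound 2; a small shift in either direction, or none beyond the scatter, is expected, written as a 1.9-fold lower number from compound 2 to compound 4 (0.27 log units; within the scatter). Compound 4 is estimated at 400 nM, with a range from 120 nM to 1300 nM, pending measurement.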

Compound 4, half-maximal inhibitory concentration: 1300 nM
Estimate against measurement, compound 4: 3.3-fold (0.51 log units) below; measured number inside the range.
By their numbers in this assay, from the lowest: compound 3; then compound 1; then compounds 2 and 4 (each within the scatter of the next).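

At the nitrogen on an aromatic ring, acetyl in place of hydrogen gives a 1.8-fold higher number from compound 2 to compound 4 (0.24 log units; within the scatter) in this assay, so amino to acetamido is a change that this read-out does not separate from repeat measurement. The earlier compounds shown here carried an amide on the pendant phenyl ring only together with a substituent on the core, whereas this pair reads the acylation of that nitrogen alone, on a core without such a substituent, and finds neither a gain nor a loss beyond the scatter. Nothing in hand gives a measured reason for this flat step, and the result stands as an observation only.

Still open, on these data alone, is how far this tolerance extends at that nitrogen: a benzoyl group, a longer acyl chain such as butanoyl, a methanesulfonyl group or a simple methyl group on the same nitrogen could each read differently from acetyl. Within the data shown here, also open is whether the same flat step holds on a core bearing pyridin-3-yl or cyclopentyl, since the one pair at this nitrogen has neither group on its core.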